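Rearranging a Ring Group on the Amide Carbonyl

The compounds below may be only part of what the source reports. "The series", "measured", "known", "first", "only" and "open" are said of these compounds alone.

Measured in a functional assay on A2780 cells (Homo sapiens) for inhibition, read by sulforhodamine B assay, with a stated time of 72 h; a lower number here means a stronger inhibitor, a higher number a weaker inhibitor:
Compound 1 `O=C(NCc1ccc(S(=O)(=O)N2CCCCC2)cc1)c1cc2cnccc2o1`: 1500 nM
Compound 2 `Cn1c(C(=O)NCc2ccc(S(=O)(=O)c3ccccc3)cc2)cc2cnccc21`: > 10000 nM (a limit, not a number)
Compound 3 `O=C(NCc1ccc(S(=O)(=O)N2CCCCC2)cc1)c1ccn2ccnc2c1`: > 10000 nM (a limit, not a number)

Compound 3 stands at the limit of > 10000 nM in this assay, at which 2 of the 3 values shown sit. Compound 4 `O=C(NCc1ccc(S(=O)(=O)N2CCCCC2)cc1)c1ccn2cncc2c1` has the same atoms as compound 3, joined differently. The change is a group of 9 heavy atoms (7 carbon, 2 nitrogen; one five-membered aromatic ring with 2 hetero atoms, one six-membered aromatic ring with 1 hetero atom) in place of a group of 9 heavy atoms (7 carbon, 2 nitrogen; one five-membered aromatic ring with 2 hetero atoms, one six-membered aromatic ring with 1 hetero atom), on a carbonyl carbon. Among the compounds with values here, one measured step bears on it, a swap at the same place: an at least 6.6-fold higher number from compound 1 to compound 3 (0.82 log units; beyond the scatter). That step shows that a change of this group can move the reading beyond the scatter. Any visible step in this assay is expected to run toward a lower number and to be of similar size, although compound 4 may also stay at the limit. The expected step is an at least 2.0-fold lower number from compound 3 to compound 4 (0.30 log units; that floor lies within the scatter). For compound 4 the estimate is 5000 nM, with an expected range of 700 nM to 30000 nM.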

Compound 4, half-maximal inhibitory concentration: > 10000 nM
Compound 4 was reported as a limit; the forecaster's own chance of this, stated with the estimate: 45%; at least 2.0-fold (0.30 log units) between middle value and limit.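

In this assay, compound 4 also stands at a limit, so moving the ring atoms of this group on the carbonyl carbon gives no readable value, and the step between compound 3 and compound 4 cannot be read. The step of an at least 6.6-fold higher number from compound 1 to compound 4 (0.82 log units; beyond the scatter) shows that a second arrangement with these same counts of ring atoms also falls short of the group in compound 1. The limit now dominates this small set: the limit of > 10000 nM in this assay, at which 3 of the 4 values shown sit. Which of compound 3 and compound 4 is the stronger inhibitor stays open. So does whether adding an amine or a carboxylic acid to the group in compound 1 would give a lower number.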